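Pyrazolylamino series: moving the pyrazole attachment

A few compounds are considered here, and "the series" means these few. Any claim that something is new, unique, unknown or untested is made for them only; others in the source may bear on it.

Measured:
compound 1 `CC(C)n1cc(Nc2ncc(C3CC3)c(NCCCNC(=O)C3CCC3)n2)cn1`: 4 nM
compound 2 `O=C(NCCCNc1nc(Nc2cnn(C3CCOCC3)c2)ncc1C1CC1)C1CCC1`: 2 nM
compound 3 `CC(C)c1cnc(Nc2cccc(F)c2)nc1NCCCNC(=O)C1CCC1`: > 1000 nM

Compound 1 in an assay on isolated protein for inhibition of serine/threonine-protein kinase TBK1 (Homo sapiens) (a lower number here means a stronger inhibitor, a higher number a weaker inhibitor), gives 4 nM, the higher of the two numbers; compound 2 sits a 2.0-fold lower number from compound 1 to compound 2 (0.30 log units; within the scatter), within the scatter. For compound 3 > 1000 nM is a limit of the assay, not a number (the limit of > 1000 nM in this assay, at which 1 of the 3 values shown sits).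

Compound 4 `Cn1ccc(Nc2ncc(C3CC3)c(NCCCNC(=O)C3CCC3)n2)n1` carries 1-methyl-1H-pyrazol-3-yl in place of 1-isopropyl-1H-pyrazol-4-yl on a nitrogen on an aromatic ring. Going by the values given here, the only measured step, from compound 1 to compound 2, swaps the group on the pyrazole nitrogen and is within the scatter; no measured step alters the attachment point itself, so the step into compound 4 is uncovered. Given the tolerance at this nitrogen, a modest loss is expected, a 3.8-fold higher number from compound 1 to compound 4 (0.57 log units; beyond the scatter), and compound 4 is estimated at 15 nM (range 4 nM to 60 nM).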

Compound 4, half-maximal inhibitory concentration: > 1000 nM
Compound 4: only a limit was reported (the forecaster's own chance of this, stated with the estimate: 5%); middle value at least 66-fold (1.82 log units) away from the limit.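

Changing the (1-isopropyl-1H-pyrazol-4-yl)amino group to (1-methyl-1H-pyrazol-3-yl)amino gives an at least 250-fold higher number from compound 1 to compound 4 (2.39 log units; beyond the scatter), so this position is far less tolerant than the swap at the pyrazole nitrogen suggested, where the step reads a 2.0-fold lower number from compound 1 to compound 2 (0.30 log units; within the scatter). Compound 4 stands at a limit of the assay, not a number: the limit of > 1000 nM in this assay, at which 2 of the 4 values shown sit. The step alters both the attachment point and the group on the pyrazole nitrogen, and the data do not separate the two.

Open, from the compounds shown here alone, is whether 1-methyl-1H-pyrazol-4-yl stays close to compound 1 or 1-isopropyl-1H-pyrazol-3-yl stays close to compound 4. Also open, going by these compounds, is how a pyrazole carrying a longer chain ending in an amine would fare.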